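The source may hold more compounds than are shown below. What is called first, only, known or untested is meant among the compounds shown, and "the series" means these compounds.

Measured in a functional assay (Nicotiana tabacum); a higher number here means a weaker inhibitor, a lower number a stronger inhibitor:
- compound 1 `CCCCCCCNc1nc(SC)nc2ncccc12`: 4070 nM
- compound 2 `CSc1nc(NC2CC2)c2cccnc2n1`: 4900 nM
- compound 3 `CSc1nc(NC2CCCC2)c2cccnc2n1`: 490 nM

Compound 3, at 490 nM, has the lowest number of the three, and its gaps to compound 1 and compound 2 lie beyond the scatter. Compound 4 `COCCNc1nc(SC)nc2ncccc12` has not yet been measured. It carries 2-methoxyethyl in place of cyclopentyl on a nitrogen on an aromatic ring.

Within the data shown here, no measured step makes this exact exchange. The nearest is a 10-fold lower number from compound 2 to compound 3 (1.00 log units; beyond the scatter), which shows that the group on this nitrogen can move the number substantially. Among the measured compounds shown here, compound 1, whose heptyl chain has no ring, gives 4070 nM, so the one open-chain example sits far from compound 3. The 2-methoxyethyl group also has no ring, so a move towards a higher number, similar in size to the measured step, is expected. The estimated step is a 6.1-fold higher number from compound 3 to compound 4 (0.79 log units; beyond the scatter). Compound 4 is estimated at 3000 nM, with an expected range from 1000 nM to 9000 nM.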

Compound 4, half-maximal inhibitory concentration: 2530 nM
Estimate against measurement, compound 4: 1.2-fold (0.07 log units) above; low and high end bracket the measured number.
By their numbers in this assay, from the lowest: compound 3; then compounds 4, 1 and 2 (each within the scatter of the next).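

In this assay, 2-methoxyethyl on this nitrogen gives a 5.2-fold higher number from compound 3 to compound 4 (0.71 log units; beyond the scatter), so this open chain, with its oxygen, does not match cyclopentyl. The other two steps, a 1.9-fold lower number from compound 2 to compound 4 (0.29 log units; within the scatter) and a 1.6-fold lower number from compound 1 to compound 4 (0.21 log units; within the scatter), leave compound 4 level with both compound 2 and compound 1: a much shorter chain carrying an oxygen reads the same as heptyl and cyclopropyl, and among these four compounds only compound 3 stands apart. No measurement offers an explanation for this.

Compound 2 shows that a ring alone is not enough, but whether ring size accounts for the low number of compound 3 remains open, as cyclobutyl and cyclohexyl are not among the compounds shown. Nor do they show whether a tetrahydropyranyl ring, which puts an oxygen into the ring, would stay near compound 3 or fall in with compound 4.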